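Adding a Second Fluorine to a Carbamate Side Chain

A few compounds are considered here, and "the series" means these few. Any claim that something is new, unique, unknown or untested is made for them only; others in the source may bear on it.

Measured compounds:
- compound 1, `CCOc1cc(=O)n(CCCO)c2c1CC(C/C=C(\C)CCC=C(C)C)C(C)(C)C2`, 67.8%
- compound 2, `CC(C)=CCC/C(C)=C/CC1Cc2c(OCCCNC(=O)c3cccs3)cc(=O)n(CCCO)c2CC1(C)C`, 72.8%
- compound 3, `CC(C)=CCC/C(C)=C/CC1Cc2c(OC(=O)Nc3cccc(F)c3)cc(=O)n(CCCO)c2CC1(C)C`, 52.3%

These three compounds were tested in a functional assay on PANC-1 cells (Homo sapiens) for inhibition, read by MTT assay, with a stated time of 24 h, tested at 10 uM; on this read-out lower numbers stand for less inhibition and higher numbers for more inhibition at the one concentration tested (going by the name of the read-out). Compound 3 gives the lowest of the three numbers: the step of a number 15.5 percentage points lower from compound 1 to compound 3 (beyond the scatter) and the step of a number 20.5 percentage points lower from compound 2 to compound 3 (beyond the scatter) both point downward and both lie beyond the scatter, whereas the step of a number 5 percentage points higher from compound 1 to compound 2 (within the scatter) stays within it.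

Compound 4, `CC(C)=CCC/C(C)=C/CC1Cc2c(OC(=O)Nc3ccc(F)cc3F)cc(=O)n(CCCO)c2CC1(C)C`, is not yet measured. It differs from compound 3 only on the amide-type nitrogen whose other neighbour is the carbonyl carbon: 2,4-difluorophenyl in place of 3-fluorophenyl on an amide-type nitrogen.

Among the compounds with values here, none of the measured steps touches this part of the molecule; they all concern what sits on the oxygen on the aromatic ring, and each of them keeps a single fluorophenyl group unchanged. There is therefore no measured evidence on how a second fluorine on that ring shifts the read-out. The step of a number 0.3 percentage points lower from compound 3 to compound 4 (within the scatter) is thus expected to stay within the scatter. Compound 4 is estimated at 52%, between 35% and 70%.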

Compound 4, a percentage reported as inhibition, at one concentration (the size of the read-out at that concentration, not a potency): 33.7%
Estimate against measurement, compound 4: 18.3 percentage points above, and the stated range ends above it.
By their numbers in this assay, from the lowest: compound 4; then compound 3; then compounds 1 and 2 (each within the scatter of the next).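

In this assay, within the data shown here, the group on the amide-type nitrogen clearly matters: changing 3-fluorophenyl to 2,4-difluorophenyl gives a number 18.6 percentage points lower from compound 3 to compound 4 (beyond the scatter) and so shows an effect at a site that no earlier step had touched. With this new group, the changes on the oxygen on the aromatic ring also become large: replacing ethyl with (2,4-difluorophenyl)carbamoyl gives a number 34.1 percentage points lower from compound 1 to compound 4 (beyond the scatter) and replacing 3-(((thiophen-2-yl)carbonyl)amino)propyl with it gives a number 39.1 percentage points lower from compound 2 to compound 4 (beyond the scatter) in the same read-out. Nothing available here explains the drop in inhibition.

These compounds cannot separate the effect of having a second fluorine from that of the fluorines sitting at different ring positions, since the change from 3-fluorophenyl to 2,4-difluorophenyl alters both at once. As far as these compounds go, it also remains open how an unsubstituted phenyl, a chlorophenyl or a methoxyphenyl group on that nitrogen would read.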